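A few compounds are considered here, and "the series" means these few. Any claim that something is new, unique, unknown or untested is made for them only; others in the source may bear on it.

Measured so far in a functional assay on RXF 393 cells (Homo sapiens) for inhibition, read by sulforhodamine B assay, with a stated time of 48 h; a higher number here means a weaker inhibitor of growth, a lower number a stronger inhibitor of growth:
compound 1 `COc1cc(-c2nn(-c3cccc(NC(=O)Nc4ccc(Cl)c(Cl)c4)c3)cc2-c2ccncc2)ccc1Cl` gives 859 nM
compound 2 `COc1cc(-c2nn(-c3cccc(NC(=O)Nc4ccc(Cl)c(C(F)(F)F)c4)c3)cc2-c2ccncc2)ccc1Cl` gives 1180 nM

Compound 2 holds the higher of the two numbers, its nearest neighbour being compound 1; the step of a 1.4-fold higher number from compound 1 to compound 2 (0.14 log units; within the scatter) is within the scatter, so the two compounds cannot be ordered against each other. Compound 3 `COc1cc(-c2nn(-c3cccc(NC(=O)c4ccccc4)c3)cc2-c2ccncc2)ccc1Cl` is the next member. Its change from compound 2 is phenyl in place of (4-chloro-3-(trifluoromethyl)phenyl)amino on a carbonyl carbon. For the measured compounds named here, the only measured step, a 1.4-fold higher number from compound 1 to compound 2 (0.14 log units; within the scatter), swaps one substituent for another on the very aromatic ring that is now removed altogether, and it stayed within the scatter; it does not show what removal of the whole (4-chloro-3-(trifluoromethyl)phenyl)amino group does. Going by the values given here, no measured step covers a change of this size, so the expectation rests on that alone. Compound 3 is expected to give 5000 nM in this assay, in the range 1500 nM to 20000 nM, an estimated step of a 4.2-fold higher number from compound 2 to compound 3 (0.63 log units; beyond the scatter) towards a weaker inhibitor, with a wide range.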

Compound 3, concentration for 50% growth inhibition: 646 nM
For compound 3 the middle estimate is 7.7-fold (0.89 log units) above the measured one; measured number below the stated range.
By their numbers in this assay, from the lowest: compounds 3, 1 and 2 (each within the scatter of the next).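

In this assay, phenyl in place of (4-chloro-3-(trifluoromethyl)phenyl)amino on the carbonyl carbon gives a 1.8-fold lower number from compound 2 to compound 3 (0.26 log units; within the scatter), and phenyl in place of (3,4-dichlorophenyl)amino on that carbon gives a 1.3-fold lower number from compound 1 to compound 3 (0.12 log units; within the scatter). This position therefore accepts more than a swap of one ring substituent: the whole arylamino group can give way to phenyl, losing the amino nitrogen, its hydrogen-bond donor and the ring halogen substituents, with no readable difference in growth inhibition among the three compounds. No measurement at hand explains this result.

As far as these compounds go, it remains open whether a much smaller group on the carbonyl carbon, such as methyl, or a saturated ring such as morpholine would stay within the same range. From the compounds shown here alone, it is equally open whether a carboxylic acid or an amine on the entering phenyl would move the number beyond the scatter.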